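Changing the Aryl Group of Compound 1

The source may hold more compounds than are shown below. What is called first, only, known or untested is meant among the compounds shown, and "the series" means these compounds.

For the measured compounds named here, in a functional assay on LNCaP cells (Homo sapiens) for antiproliferative activity, read by propidium iodide staining, with a stated time of 96 h (a lower number here means a stronger inhibitor, a higher number a weaker inhibitor), compound 1 (`CC(O)(COc1cccc(C(F)(F)F)c1)C(=O)Nc1ccc(S(F)(F)(F)(F)F)cc1`) gives 24700 nM, the higher of the two numbers measured so far, so it is the weaker inhibitor of the pair. Compound 2 (`CC(O)(COc1cccc(OC(F)(F)F)c1)C(=O)Nc1ccc(S(F)(F)(F)(F)F)cc1`) gives 11000 nM in the same test. Going by the values given here, only one measured step is available as a guide: a 2.2-fold lower number from compound 1 to compound 2 (0.35 log units; beyond the scatter), seen when trifluoromethoxy takes the place of trifluoromethyl on an aromatic carbon.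

Compound 3 (`CC(O)(COc1ccc(C#N)c(F)c1)C(=O)Nc1ccc(S(F)(F)(F)(F)F)cc1`) has not been measured. It carries 4-cyano-3-fluorophenyl in place of 3-(trifluoromethyl)phenyl on an oxygen on a saturated carbon. Among the compounds with values here, this is a different replacement from the one in compound 2, so that single step offers only a loose guide to size and direction. With so little evidence, a modest move toward a lower number is the cautious expectation, and a wide range is needed. In this assay the expected change is a 2.1-fold lower number from compound 1 to compound 3 (0.31 log units; beyond the scatter), and a step in the opposite direction cannot be ruled out. The estimated value for compound 3 is 12000 nM (expected range 4000 nM to 35000 nM).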

Compound 3, half-maximal inhibitory concentration: 100000 nM
Beside the measured number, compound 3's estimate is 8.3-fold (0.92 log units) below it; measured number above the stated range.
By their numbers in this assay, from the lowest: compound 2; then compound 1; then compound 3.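

In this assay, for the compounds shown here, putting 4-cyano-3-fluorophenyl in place of 3-(trifluoromethyl)phenyl on the oxygen gives a 4.0-fold higher number from compound 1 to compound 3 (0.61 log units; beyond the scatter) and so makes the compound a weaker inhibitor, whereas the only earlier change at this aryl group gave a 2.2-fold lower number from compound 1 to compound 2 (0.35 log units; beyond the scatter) and made it a stronger one. The number can therefore move in either direction when this aryl group is changed, and of the two replacements shown, only the one in compound 2 improves on compound 1. Nothing measured here explains the loss seen with compound 3.

Compound 3 differs from compound 1 in more than one feature of the ring, with a nitrile and a fluorine both present and the trifluoromethyl gone, so the compounds shown leave open what the nitrile or the fluorine does on its own. Also open, on these data alone, is whether a ring bearing a chlorine or a methoxy, or an amine nitrogen in place of the oxygen, would give a lower number than compound 2 does.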